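The compounds below may be only part of what the source reports. "The series", "measured", "known", "first", "only" and "open" are said of these compounds alone.

Of the compounds shown here, three sharing one core have been read so far in an ADME assay on cells (Lymphocyte, Homo sapiens) for cytotoxicity, read by MTT assay, with a stated time of 48 h; on this read-out lower numbers stand for stronger inhibition and higher numbers for weaker inhibition. Compound 1 `COC(=O)/C(=C\c1ccc(OC(=O)c2cc(OC)cc(OC)c2)cc1)Sc1ccnc2cc(Cl)ccc12` gives 84100 nM. Compound 2 `COC(=O)/C(=C\c1ccc(OC(=O)c2ccc(OC)cc2OC)cc1)Sc1ccnc2cc(Cl)ccc12` gives 41600 nM. Compound 3 `COC(=O)/C(=C\c1ccc(OC(=O)c2cc(OC)c(OC)cc2OC)cc1)Sc1ccnc2cc(Cl)ccc12` gives 52500 nM, a value within the scatter of both compound 1 and compound 2.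

The next compound to be read is compound 4 `COC(=O)/C(=C\c1ccc(OC(=O)c2ccc(OC)c(OC)c2OC)cc1)Sc1ccnc2cc(Cl)ccc12`. Relative to compound 3, it carries 2,3,4-trimethoxyphenyl in place of 2,4,5-trimethoxyphenyl on a carbonyl carbon. Among the measured compounds shown here, the atoms are the same, joined differently, and no measured compound yet carries this group.

For the measured compounds named here, three measured steps bear on the change, all of them swaps or additions in the same aryl group. The largest is a 2.0-fold lower number from compound 1 to compound 2 (0.31 log units; beyond the scatter), which is modest and only just clears the scatter. The other two, a 1.6-fold lower number from compound 1 to compound 3 (0.20 log units; within the scatter) and a 1.3-fold higher number from compound 2 to compound 3 (0.10 log units; within the scatter), stay within it. Changes at this group have therefore moved the number only slightly in this assay, and in no consistent direction that three compounds could establish.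

No step beyond the scatter is expected here, and the estimated step is a 1.0-fold higher number from compound 3 to compound 4 (0.02 log units; within the scatter). Compound 4 is expected at 55000 nM, with an estimated range of 31000 nM to 95000 nM.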

Compound 4, half-maximal inhibitory concentration: 22400 nM
Compound 4: the middle estimate sits 2.5-fold (0.39 log units) above what was measured; the whole stated range lies above it.
By their numbers in this assay, from the lowest: compounds 4, 2, 3 and 1 (each within the scatter of the next, the first and the last beyond it).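

In this assay the three methoxy groups change only their arrangement, and a 2.3-fold lower number from compound 3 to compound 4 (0.37 log units; beyond the scatter) is beyond the scatter, so at this aryl group on a carbonyl carbon the arrangement of the same atoms can alone shift the number, which compounds 1 to 3 had not separated from a change in the number of methoxy groups. Methoxy in place of hydrogen on an aromatic carbon gives a 1.9-fold lower number from compound 2 to compound 4 (0.27 log units; within the scatter) and stays within the scatter, so compound 4 cannot be placed ahead of compound 2, while a 3.8-fold lower number from compound 1 to compound 4 (0.57 log units; beyond the scatter) is the widest step in the series and is still modest. No measurement on hand accounts for the difference between the 2,3,4-trimethoxyphenyl and 2,4,5-trimethoxyphenyl groups.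

The compounds shown carry only methoxy groups on this aryl ring, so it remains open whether an amine, a carboxylic acid or a longer chain such as ethoxy in their place would move the number further. Going by these compounds, whether the same arrangement would give a similar step on another core also remains open.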